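Acetylating the hydroxy group of compound 2

This account rests on a few compounds, and the source may have more. Where it says the series, first, only, none or still open, it means among the compounds named here.

- compound 1 `COc1ccc2cc(-c3ccccc3)c(O)nc2c1`: 10000 nM
- compound 2 `COc1cc(OC)c2cc(-c3ccc(O)cc3)c(=O)n(C)c2c1`: 10000 nM

Both values come from a functional assay on LoVo cells (Homo sapiens) for cytotoxicity, read by colorimetric assay and MTT assay; on this read-out higher numbers stand for weaker inhibition and lower numbers for stronger inhibition. In this assay compound 2 stands level with compound 1, and the gap between them lies within the scatter. Among the compounds with values here, the two compounds differ in more than one place, so their values give no step for any single change.

The next compound is compound 3 `COc1cc(OC)c2cc(-c3ccc(OC(C)=O)cc3)c(=O)n(C)c2c1`, which differs from compound 2 by acetyl in place of hydrogen on an oxygen on an aromatic ring, or hydroxy to acetoxy. Within the data shown here, no measured pair shows this change. No step beyond the scatter is expected in either direction, and the expectation rests only on compound 2 at 10000 nM.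

The expected change is a 1.3-fold lower number from compound 2 to compound 3 (0.10 log units; within the scatter). For compound 3 the estimate is 8000 nM, with an expected range of 3000 nM to 15000 nM.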

Compound 3, half-maximal inhibitory concentration: 10000 nM
Compound 3: the middle estimate sits 1.3-fold (0.10 log units) below what was measured, and the stated range covers the measured number.
By their numbers in this assay, from the lowest: compounds 1, 2 and 3 (each within the scatter of the next).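

In this assay, within the data shown here, replacing hydroxy with acetoxy gives no change at the digits printed from compound 2 to compound 3 (within the scatter), the only single-place step. This position therefore accepts acetyl in place of hydrogen on the oxygen with the read-out unmoved, which compound 1 and compound 2 alone could not show. Nothing at hand bears on why this step is flat.

Still open, as far as these compounds go, is whether a methyl ether or a longer chain on this oxygen, or an amine or a carboxylic acid in place of the hydroxy group, would move the number beyond the scatter. Also open, from the compounds shown here alone, is whether the same change would read the same way on another core, such as that of compound 1.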